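The compounds below may be only part of what the source reports. "The series", "measured", "known", "first", "only" and "open" are said of these compounds alone.

Working notes on the series. Compound 1 `CN1CCN(CCCOc2cccc3nc(Nc4ccc(F)c(F)c4)ccc23)CC1` and compound 3 `CN1CCN(CCCOc2cccc3nc(Nc4cc(Cl)cc(Cl)c4)ccc23)CC1` share one core and differ only in the aryl group on the amine; compound 2 `CN1CCN(CCCOc2cccc3nc(Nc4cccc(Cl)c4)ccc23)CC1` belongs to the same set. In a functional assay on MDA-MB-231 cells (Homo sapiens) for inhibition, read by sulforhodamine B assay, with a stated time of 48 h (a lower number here means a stronger inhibitor of growth, a higher number a weaker inhibitor of growth), compound 1 gives 937 nM, compound 3 gives 1570 nM, and for compound 2 this assay gives "not determined" (no result reported). Compound 3 therefore stands alongside compound 1, the step of a 1.7-fold higher number from compound 1 to compound 3 (0.22 log units; within the scatter) lying within the scatter. Compound 4 `CN1CCN(CCCOc2cccc3nc(Nc4ccc(Cl)c(F)c4)ccc23)CC1` takes the next step: 4-chloro-3-fluorophenyl in place of 3,5-dichlorophenyl on a nitrogen on an aromatic ring. Within the data shown here, the only measured step at this position, a 1.7-fold higher number from compound 1 to compound 3 (0.22 log units; within the scatter), is within the scatter, so no shift beyond the scatter is expected for compound 4, a step of about a 1.3-fold lower number from compound 3 to compound 4 (0.12 log units; within the scatter). Compound 4 is estimated at 1200 nM, range 500 nM to 3000 nM.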

Compound 4, concentration for 50% growth inhibition: 1680 nM
For compound 4 the middle estimate is 1.4-fold (0.15 log units) below the measured one; the measured number falls inside the stated range.
By their numbers in this assay, from the lowest: compounds 1, 3 and 4 (each within the scatter of the next).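

Two further steps at this position, a 1.1-fold higher number from compound 3 to compound 4 (0.03 log units; within the scatter) and a 1.8-fold higher number from compound 1 to compound 4 (0.25 log units; within the scatter), show that in this assay the numbers for all three aryl groups with a measured value stay within the scatter of one another. The second step also isolates chloro in place of fluoro on an aromatic carbon, a single-atom change that leaves the number within the scatter. No measurement is available that explains this result.

As far as these compounds go, whether a methoxy group, a nitrile or a carboxylic acid on this aryl ring would move the number beyond the scatter remains open. So does the effect of a shorter or longer chain on the shared core.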